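Methyl for methoxy in the bis-ethylthio series

The source may hold more compounds than are shown below. What is called first, only, known or untested is meant among the compounds shown, and "the series" means these compounds.

Measured in an ADME assay on the whole organism (Mus musculus, strain CD-1) for pharmacokinetics; a lower number here means slower removal, a higher number faster removal of the compound:
- compound 1 `COc1cc([C@](O)(CCN(C)C)[C@@H](c2cc3cc(C#N)ccc3nc2OC)c2cccc(C)c2F)cc(OC(F)F)n1`: 13 mL/min/kg
- compound 2 `CCSc1cc([C@](O)(CCN(C)C)[C@@H](c2cc3cc(C#N)ccc3nc2OC)c2cccc(OC)c2F)cc(SCC)n1`: 29 mL/min/kg

Compound 2, at 29 mL/min/kg, holds the higher of the two numbers, and its gap to compound 1 lies beyond the scatter. Compound 3 `CCSc1cc([C@](O)(CCN(C)C)[C@@H](c2cc3cc(C#N)ccc3nc2OC)c2cccc(C)c2F)cc(SCC)n1` follows from compound 2 with methyl in place of methoxy on an aromatic carbon, ortho to a fluoro group (methyl in place of methoxy on an aromatic carbon). For the measured compounds named here, no measured pair isolates this change, so no step beyond the scatter is expected in this assay. The estimated step is small, a 1.1-fold lower number from compound 2 to compound 3 (0.05 log units; within the scatter). For compound 3 the expected clearance is 26 mL/min/kg, within an estimated range of 14 mL/min/kg to 46 mL/min/kg.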

Compound 3, clearance: 9.4 mL/min/kg
For compound 3 the middle estimate is 2.8-fold (0.44 log units) above the measured one; measured number outside the range, below it.
By their numbers in this assay, from the lowest: compounds 3 and 1 (each within the scatter of the next); then compound 2.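

In this assay, the change from 2-fluoro-3-methoxyphenyl to 2-fluoro-3-methylphenyl now stands as an isolated pair, with a 3.1-fold lower number from compound 2 to compound 3 (0.49 log units; beyond the scatter), so this position does register in the bis-ethylthio series. With 2-fluoro-3-methylphenyl held constant, exchanging the other aromatic group gives a 1.4-fold lower number from compound 1 to compound 3 (0.14 log units; within the scatter), so the two ethylthio groups and the methoxy and difluoromethoxy pair cannot be told apart here. No measured data on these compounds explain the step.

From the compounds shown here alone, whether the methoxy to methyl step recurs with the methoxy and difluoromethoxy pair remains open. Also open, going by these compounds, is how chloro, ethyl or hydroxyl would read at this position.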